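The source may hold more compounds than are shown below. What is called first, only, known or untested is meant among the compounds shown, and "the series" means these compounds.

Two compounds share one core and differ only in the group on a carbon with a double bond to nitrogen. Compound 1 `Cc1ccc(/C=N/Nc2ncc3c(n2)n(C2CCCC2)c(=O)c(=O)n3C)cc1C` gives 39000 nM in a functional assay on PC-3 cells (Homo sapiens) for antiproliferative activity, read by MTT assay; a higher number here means a weaker inhibitor, a lower number a stronger inhibitor. Compound 2 `COc1ccc(/C=N/Nc2ncc3c(n2)n(C2CCCC2)c(=O)c(=O)n3C)cc1` gives 26300 nM in this assay, and the step of a 1.5-fold lower number from compound 1 to compound 2 (0.17 log units; within the scatter) lies within the usual scatter, so the two compounds cannot be told apart on these numbers. Compound 3 `Cn1c(=O)c(=O)n(C2CCCC2)c2nc(N/N=C/c3cc([N+](=O)[O-])ccc3Cl)ncc21` carries the change (2-chloro-5-nitrophenyl in place of 4-methoxyphenyl on a carbon with a double bond to nitrogen). Among the compounds with values here, the only measured step that bears on this change, a 1.5-fold lower number from compound 1 to compound 2 (0.17 log units; within the scatter), also exchanged the group at the same place and gave no movement beyond the scatter. On that basis a step of a 1.0-fold lower number from compound 2 to compound 3 (0.00 log units; within the scatter) is expected for compound 3, with nothing to suggest a shift beyond the scatter in either direction. The estimate for compound 3 in this assay is 26000 nM, with a range from 8000 nM to 85000 nM.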

Compound 3, half-maximal inhibitory concentration: 9260 nM
For compound 3 the middle estimate is 2.8-fold (0.45 log units) above the measured one; low and high end bracket the measured number.
By their numbers in this assay, from the lowest: compound 3; then compounds 2 and 1 (each within the scatter of the next).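

In this assay, this position does respond to the group it carries: 2-chloro-5-nitrophenyl in place of 4-methoxyphenyl gives a 2.8-fold lower number from compound 2 to compound 3 (0.45 log units; beyond the scatter) and, in place of 3,4-dimethylphenyl, a 4.2-fold lower number from compound 1 to compound 3 (0.62 log units; beyond the scatter). Both steps lie beyond the scatter, whereas the exchange between the two earlier groups did not, so a change on the carbon with a double bond to nitrogen can modestly shift the number while the shared core stays the same. Nothing available here explains this shift.

The chlorine and the nitro group entered together, so the compounds shown leave open whether one alone, on a phenyl ring carrying only chloro or only nitro, would give the same step. As far as these compounds go, how an amine or a carboxylic acid on that ring would behave also remains open.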